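A small change on a compound at the limit

The source may report more compounds than this note shows. Statements on the series, on what has been measured and on what is new or still open speak of the compounds shown alone.

Measured in a functional assay on Rec1 cells (Homo sapiens) for inhibition, read by luminescence and CellTiter-Glo, with a stated time of 72 h; a lower number here means a stronger inhibitor, a higher number a weaker inhibitor:
Compound 1 `O=C(CCl)N1CCCC(n2nc(-c3ccc(Oc4ccccc4)cc3)cc2CO)C1`: 400 nM
Compound 2 `C=CC(=O)Nc1ccc(Cn2nc(-c3ccc(Oc4ccccc4)cc3)cc2C(=O)O)cc1`: > 60000 nM (a limit)

Only compound 1 has a true number, 400 nM, in this assay. For compound 2, this assay reports only a limit, > 60000 nM, and no number. Compound 2 thus stands at the limit of > 60000 nM in this assay, at which 1 of the 2 values shown sits.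

Compound 3 `C/C=C/C(=O)Nc1ccc(Cn2nc(-c3ccc(Oc4ccccc4)cc3)cc2C(=O)O)cc1` has not yet been measured. It differs from compound 2 in one place, with prop-1-en-1-yl in place of vinyl on a carbonyl carbon. The rest of the structure stays the same. Going by the values given here, no two measured compounds differ in only one place, so no measured step is available as a guide.

The expectation therefore rests on the smallness of this change and on compound 2, whose > 60000 nM is a limit. No shift beyond the usual scatter is expected, and the assay may well report a limit again. The expected size of the step is a number no higher from compound 2 to compound 3 (the limit leaves the size open). For compound 3 the estimated value is 60000 nM, with an expected range from 25000 nM to 100000 nM.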

Compound 3, half-maximal inhibitory concentration: 23600 nM
Compound 3: middle estimate off by 2.5-fold (0.41 log units), on the high side, and the stated range ends above it.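

In this assay, putting prop-1-en-1-yl in place of vinyl on a carbonyl carbon, whose other neighbour is an amide-type nitrogen, gives an at least 2.5-fold lower number from compound 2 to compound 3 (0.40 log units; beyond the scatter). This shows that the position is not silent in this series: a change this small, with no ring, charge or hydrogen-bond donor or acceptor entering or leaving, is enough to move the read-out. Compound 3 gives a true number, 23600 nM. The size of the step remains only a bound, because one end of it is a limit and not a number: the limit of > 60000 nM in this assay, at which 1 of the 3 values shown sits.

The compounds shown leave open whether a longer chain in place of prop-1-en-1-yl, or an amine carried on that chain, would move the number further in the same direction, and so whether this single step is the start of a trend or stands alone. On these data alone, compound 1 differs from compound 2 and compound 3 in more than one place, so its value says nothing about this change, and whether the same change would have any effect on the core of compound 1 also stays open.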